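A Methylated Imidazole Directly on the Chain Carbon

A few compounds are considered here, and "the series" means these few. Any claim that something is new, unique, unknown or untested is made for them only; others in the source may bear on it.

Three analogues sharing one core have been measured in a functional assay on CHO cells for antagonist activity at prostaglandin E2 receptor EP3 subtype (Homo sapiens), read by cAMP accumulation; on this read-out lower numbers stand for stronger inhibition and higher numbers for weaker inhibition. Compound 1 `CC(C)C(c1ccc(-c2ccc3cccc(F)c3c2)[nH]c1=O)N1CCCCS1(=O)=O` gives 122 nM, compound 2 `CC(C)C(Cc1ncc[nH]1)c1ccc(-c2ccc3cccc(F)c3c2)[nH]c1=O` gives 76 nM, and compound 3 `CC(C)C(c1cnc(N)s1)c1ccc(-c2ccc3cccc(F)c3c2)[nH]c1=O` gives 39 nM. Compound 2 thus stands second highest of the three, with a 1.6-fold lower number from compound 1 to compound 2 (0.21 log units; within the scatter) and a 1.9-fold lower number from compound 2 to compound 3 (0.29 log units; within the scatter). The new compound 4 `Cc1c[nH]c(C(c2ccc(-c3ccc4cccc(F)c4c3)[nH]c2=O)C(C)C)n1` carries the change (4-methyl-1H-imidazol-2-yl in place of (1H-imidazol-2-yl)methyl on a saturated chain carbon bound to an aromatic carbon and a saturated chain carbon). The relevant steps are the replacements at that same chain carbon: a 3.1-fold lower number from compound 1 to compound 3 (0.50 log units; beyond the scatter), where a five-membered aromatic ring sits directly on the chain carbon, and a 1.6-fold lower number from compound 1 to compound 2 (0.21 log units; within the scatter). Both point the same way but are modest, so a small lowering or none beyond the scatter is expected, a 1.3-fold lower number from compound 2 to compound 4 (0.10 log units; within the scatter). Compound 4 is therefore estimated at 60 nM, within 25 nM to 150 nM.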

Compound 4, half-maximal inhibitory concentration: 36 nM
Beside the measured number, compound 4's estimate is 1.7-fold (0.22 log units) above it, and the stated range covers the measured number.
By their numbers in this assay, from the lowest: compounds 4, 3, 2 and 1 (each within the scatter of the next, the first and the last beyond it).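

In this assay, setting the imidazole directly on the saturated chain carbon, with the methyl on the ring, gives a 2.1-fold lower number from compound 2 to compound 4 (0.32 log units; beyond the scatter). With that attachment, the imidazole and the 2-amino-1,3-thiazol-5-yl group cannot be told apart, at a 1.1-fold lower number from compound 3 to compound 4 (0.03 log units; within the scatter), while a 3.4-fold lower number from compound 1 to compound 4 (0.53 log units; beyond the scatter) shows compound 4 clear of the six-membered non-aromatic ring of compound 1. Nothing available explains these steps. The compounds shown do not separate the effect of the direct attachment from that of the methyl, which 1H-imidazol-2-yl itself on this carbon would do. From the compounds shown here alone, how a carboxylic acid at this carbon would compare also remains open.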